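A few compounds are considered here, and "the series" means these few. Any claim that something is new, unique, unknown or untested is made for them only; others in the source may bear on it.

Measured in a functional assay on MGC-803 cells (Homo sapiens) for inhibition, read by MTT assay, with a stated time of 72 h; a higher number here means a weaker inhibitor, a lower number a stronger inhibitor:
- compound 1 `Cc1ccc(N2CCCC2)c(C(=O)Nc2ccc(CNC(=O)OCc3cccnc3)cc2)c1`: 19100 nM
- compound 2 `O=C(NCc1ccc(NC(=O)c2cc(F)ccc2N2CCCC2)cc1)OCc1cccnc1`: 10700 nM
- compound 3 `O=C(NCc1ccc(NC(=O)c2cc(C(F)(F)F)ccc2N2CCCC2)cc1)OCc1cccnc1`: 42100 nM

Compound 3 has the highest number of the three, and its steps to both others lie beyond the scatter, so it is the weakest inhibitor of this small set.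

Compound 4 `O=C(NCc1ccc(NC(=O)c2cc(Br)ccc2N2CCCC2)cc1)OCc1cccnc1` has not been measured. Its difference from compound 3 is bromo in place of trifluoromethyl on an aromatic carbon, para to a pyrrolidin-1-yl group.

Among the measured compounds shown here, three measured steps concern this carbon. Two of them introduce trifluoromethyl and are modest: a 2.2-fold higher number from compound 1 to compound 3 (0.34 log units; beyond the scatter) and a 3.9-fold higher number from compound 2 to compound 3 (0.59 log units; beyond the scatter). The third, for fluoro in place of methyl, is a 1.8-fold lower number from compound 1 to compound 2 (0.25 log units; within the scatter), which stays within the scatter. For the measured compounds named here, no bromo compound has been measured, so the comparison is indirect.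

Bromo is expected to behave more like methyl in compound 1 at 19100 nM and fluoro in compound 2 at 10700 nM than like trifluoromethyl. A modest drop in the number is therefore expected, estimated as a 2.1-fold lower number from compound 3 to compound 4 (0.32 log units; beyond the scatter).

For compound 4 the estimated value in this assay is 20000 nM, with an expected range from 9000 nM to 45000 nM.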

Compound 4, half-maximal inhibitory concentration: 45700 nM
Compound 4: middle estimate off by 2.3-fold (0.36 log units), on the low side; the whole stated range lies below it.
By their numbers in this assay, from the lowest: compounds 2 and 1 (each within the scatter of the next); then compounds 3 and 4 (each within the scatter of the next).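

In this assay, bromo in place of trifluoromethyl on the aromatic carbon para to a pyrrolidin-1-yl group gives no separable change (a 1.1-fold higher number from compound 3 to compound 4 (0.04 log units; within the scatter)), so the two groups cannot be told apart at this position, although bromo has 1 heavy atom and trifluoromethyl has 4. Bromo separates from both fluoro (a 4.3-fold higher number from compound 2 to compound 4 (0.63 log units; beyond the scatter)) and methyl (a 2.4-fold higher number from compound 1 to compound 4 (0.38 log units; beyond the scatter)), so the high number of compound 3 is no longer a lone result: among these four compounds, the bromo and trifluoromethyl compounds form one group and the fluoro and methyl compounds another, with each pair lying within the scatter. The compounds shown offer no measurement that accounts for this grouping.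

On these data alone, it remains open whether other groups at this carbon, such as chloro, methoxy, nitrile, an amine or a carboxylic acid, would fall with the fluoro and methyl pair, with the bromo and trifluoromethyl pair, or outside both. The compounds shown also leave open how the parent compound with hydrogen on this carbon compares, and so whether any of these four groups improves on it or weakens it.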